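The source may hold more compounds than are shown below. What is called first, only, known or untested is meant among the compounds shown, and "the series" means these compounds.

In a toxicity assay on L6 cells (Rattus norvegicus) for inhibition, read by microscopy and resazurin assay, with a stated time of 70 h (a lower number here means a stronger inhibitor, a higher number a weaker inhibitor), compound 1 `CC1(C)CCc2c(ccc(CNCCCc3ccccc3)c2O)O1` gives 27000 nM. In this assay compound 2 `CC1(C)CCc2c(ccc(CNCCCCc3ccccc3)c2O)O1` gives 15000 nM. In this assay compound 3 `CC1(C)CCc2cc(CNCCCc3ccccc3)c(O)cc2O1` gives 6500 nM.

Compound 1 and compound 3 are built from the same atoms joined differently; the difference between the two cores is not broken down here. Among the three, compound 3 has the lowest number, beyond the scatter from both others. From compound 1 to compound 2 the change is benzyl in place of phenyl on a saturated chain carbon, three bonds along the chain from an amine nitrogen, and it made a 1.8-fold lower number from compound 1 to compound 2 (0.26 log units; within the scatter).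

Compound 4 `CC1(C)CCc2cc(CNCCCCc3ccccc3)c(O)cc2O1` has not been measured in this assay. It differs from compound 3 by benzyl in place of phenyl on a saturated chain carbon, three bonds along the chain from an amine nitrogen, the same change at the same place as that from compound 1 to compound 2. Because a 1.8-fold lower number from compound 1 to compound 2 (0.26 log units; within the scatter) stayed within the scatter, a similarly small step is expected here, a 1.6-fold lower number from compound 3 to compound 4 (0.21 log units; within the scatter). Compound 4 is therefore estimated at 4000 nM, with a likely range from 1500 nM to 10000 nM.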

Compound 4, half-maximal inhibitory concentration: 15000 nM
For compound 4 the middle estimate is 3.8-fold (0.57 log units) below the measured one; measured number above the stated range.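

In this assay the change gave a 2.3-fold higher number from compound 3 to compound 4 (0.36 log units; beyond the scatter), so it did not behave on this core as it had on the other. Set side by side, the two steps show that the same change cannot simply be carried from one core to the other in this series: the same change on two cores in this assay, a 1.8-fold lower number (0.26 log units; within the scatter) from compound 1 to compound 2 and a 2.3-fold higher number (0.36 log units; beyond the scatter) from compound 3 to compound 4, 4.2-fold (0.62 log units) apart, beyond the scatter of two such steps. Going by these compounds alone, this rests on only two pairs of compounds, and it shows that the core matters without showing why, or what the change would do on any third core.

Going by these compounds, what a still longer chain would do on either core remains open. So does the outcome of replacing the terminal phenyl ring with a carboxylic acid.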